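Furan Replaces Benzoyl on a Piperidine Amide Series

The source may hold more compounds than are shown below. What is called first, only, known or untested is meant among the compounds shown, and "the series" means these compounds.

Of the compounds shown here, three sharing one core have been tested in an ADME assay on PC-3 cells (Homo sapiens) for cytotoxicity, read by WST assay, tested at 100 uM; a lower number here means less inhibition, a higher number more inhibition at the concentration tested (going by the name of the read-out). Compound 1 `O=C(Nc1ccc(Cl)cc1)C1CCCN(C(=O)c2cccc(-c3nccs3)c2)C1` gives 32%. Compound 2 `O=C(Nc1ccc(Cl)cc1)C1CCCN(C(=O)c2cccc(-c3cccs3)c2)C1` gives 4%. Compound 3 `O=C(c1ccccc1)c1cccc(C(=O)N2CCCC(C(=O)Nc3ccc(Cl)cc3)C2)c1` gives 0%. On these numbers compound 3 sits at the low end: the gap to compound 2 lies within the scatter of this assay, whereas compound 1 stands well above it, with a number 32 percentage points lower from compound 1 to compound 3 (beyond the scatter).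

Compound 4 `O=C(Nc1ccc(Cl)cc1)C1CCCN(C(=O)c2cccc(-c3ccco3)c2)C1` is derived from compound 3 by the change (furan-2-yl in place of benzoyl on an aromatic carbon). The group entering is a five-membered aromatic ring with one hetero atom, which compound 2 also carries, so the most relevant comparison is a number 4 percentage points lower from compound 2 to compound 3 (within the scatter), a step within the scatter. The only large movement observed, a number 32 percentage points lower from compound 1 to compound 3 (beyond the scatter), involved a different five-membered ring and does not transfer directly to this change. The step from compound 3 to compound 4 in this assay is therefore expected to be small, a number 6 percentage points higher from compound 3 to compound 4 (within the scatter), with no clear direction beyond the scatter. Compound 4 is estimated at 6%, within the range 0% to 22%.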

Compound 4, a percentage reported as inhibition, at one concentration (the size of the read-out at that concentration, not a potency): 0%
Beside the measured number, compound 4's estimate is 6 percentage points above it, within the range that was stated.
By their numbers in this assay, from the lowest: compounds 3, 4 and 2 (each within the scatter of the next); then compound 1.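

In this assay, furan-2-yl in place of benzoyl on this aromatic carbon gives no change at the digits printed from compound 3 to compound 4 (within the scatter), so exchanging a benzoyl group for a five-membered aromatic ring does not move the read-out at this position. Swapping one five-membered ring for another also stays within the scatter, at a number 4 percentage points lower from compound 2 to compound 4 (within the scatter), whereas 1,3-thiazol-2-yl alone stands apart from the other three groups, with a number 32 percentage points lower from compound 1 to compound 4 (beyond the scatter). Nothing available here explains why that one ring differs from the rest.

The compounds shown leave open whether other nitrogen-containing rings, such as 1,3-oxazol-2-yl or pyridin-2-yl, would read like 1,3-thiazol-2-yl or stay with the low group. From the compounds shown here alone, it also remains open how a group without a ring, such as an amine or a carboxylic acid, would read at this position.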